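Swapping Trifluoromethyl for Chloro on the Aromatic Ring

This account rests on a few compounds, and the source may have more. Where it says the series, first, only, none or still open, it means among the compounds named here.

Compound 1, `COCC(C(=O)N1CCN(c2cccc(C(F)(F)F)c2)CC1)N1C(=O)CCC1=O`, gives in a functional assay on the whole organism (strain Swiss) with Mus musculus as the target, with a stated time of 0.5 h (on this read-out higher numbers stand for an effect only at larger amounts of compound and lower numbers for an effect already at smaller amounts), a limit, > 120 mg/kg.
Compound 2, `CCC(C(=O)N1CCN(c2cccc(C(F)(F)F)c2)CC1)N1C(=O)CCC1=O`, gives 42.3 mg/kg.
Compound 3, `CC(C(=O)N1CCN(c2cccc(C(F)(F)F)c2)CC1)N1C(=O)CCC1=O`, gives 21 mg/kg.

Compound 3 holds the lowest of the two numbers, but compound 2 sits only a 2.0-fold lower number from compound 2 to compound 3 (0.30 log units; within the scatter) away, so the two cannot be told apart. The value of compound 1 is the limit of > 120 mg/kg in this assay, at which 1 of the 3 values shown sits. The other two stand clearly apart from it: an at least 2.8-fold lower number from compound 1 to compound 2 (0.45 log units; beyond the scatter) and an at least 5.7-fold lower number from compound 1 to compound 3 (0.75 log units; beyond the scatter), both changes at the saturated chain carbon.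

Compound 4, `CC(C(=O)N1CCN(c2cccc(Cl)c2)CC1)N1C(=O)CCC1=O`, differs from compound 3 in one place: chloro in place of trifluoromethyl on an aromatic carbon, meta to a large group. For the measured compounds named here, none of the measured steps touches this aromatic position; all three concern the chain carbon, so none of them bears directly on the new change. Going by the values given here, with no measured step pointing either way, the expectation is a change of no change at the digits printed from compound 3 to compound 4 (within the scatter), that is, none beyond the scatter. Compound 4 is therefore estimated to give 21 mg/kg, with a range from 8 mg/kg to 55 mg/kg.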

Compound 4, dose for half-maximal effect: 50.4 mg/kg
The estimate for compound 4 lay 2.4-fold (0.38 log units) below the measured number, within the range that was stated.
By their numbers in this assay, from the lowest: compounds 3, 2 and 4 (each within the scatter of the next, the first and the last beyond it). At a limit, above all of these: compound 1.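

For the compounds shown here, the earlier steps all sat on the chain carbon, so this is the first look at the aromatic position, and the change there has a visible effect: the swap of trifluoromethyl for chloro gives a 2.4-fold higher number from compound 3 to compound 4 (0.38 log units; beyond the scatter) in this assay. With chloro on this carbon, a larger amount of compound is needed for the same effect, although the step is modest and rests on a single pair of compounds. Nothing measured here tells which difference between the two groups lies behind this step.

On these data alone, it remains open how a nitrile, a methoxy group or a plain hydrogen on this aromatic carbon would read in this assay. As far as these compounds go, it is also open whether the same swap would give a step of similar size on the core of compound 2.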